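Replacing pyridazin-3-yl with 3-fluoropyridin-4-yl on a carbonyl carbon

A few compounds are considered here, and "the series" means these few. Any claim that something is new, unique, unknown or untested is made for them only; others in the source may bear on it.

In a physicochemical assay for solubility, measured as kinetic solubility, with a stated time of 1 h, at pH 7.4 (a higher number here means a more soluble compound, a lower number a less soluble compound), compound 1 (`N#CCC(=O)NC1=NN(c2ccc(Cl)c(Cl)c2)CC1`) gives 202000 nM, compound 2 (`O=C(NC1=NN(c2ccc(Cl)c(Cl)c2)CC1)c1cccnc1`) gives 4000 nM and compound 3 (`O=C(NC1=NN(c2ccc(Cl)c(Cl)c2)CC1)c1cccnn1`) gives 67000 nM, the second highest of the three numbers. Compound 4 (`O=C(NC1=NN(c2ccc(Cl)c(Cl)c2)CC1)c1ccncc1F`) has 3-fluoropyridin-4-yl in place of pyridazin-3-yl on a carbonyl carbon. The group at this place has already moved the number considerably, with a large step of a 51-fold lower number from compound 1 to compound 2 (1.70 log units; beyond the scatter) and a modest one of a 3.0-fold lower number from compound 1 to compound 3 (0.48 log units; beyond the scatter). Closest to the present change is compound 2, also a pyridinyl, with its large step of a 17-fold higher number from compound 2 to compound 3 (1.22 log units; beyond the scatter). A large step downward is therefore expected, estimated as a 6.7-fold lower number from compound 3 to compound 4 (0.83 log units; beyond the scatter). Compound 4 is expected at 10000 nM, within an estimated range of 3000 nM to 35000 nM.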

Compound 4, solubility: 36000 nM
For compound 4 the middle estimate is 3.6-fold (0.56 log units) below the measured one; measured number outside the range, above it.
By their numbers in this assay, from the lowest: compound 2; then compounds 4 and 3 (each within the scatter of the next); then compound 1.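

In this assay the 3-fluoropyridin-4-yl of compound 4 does not separate from pyridazin-3-yl (a 1.9-fold lower number from compound 3 to compound 4 (0.27 log units; within the scatter)), so these two aromatic rings read alike on this carbonyl carbon. A pyridinyl here therefore need not give a number like that of compound 2 (a 9.0-fold higher number from compound 2 to compound 4 (0.95 log units; beyond the scatter)), although cyanomethyl remains apart (a 5.6-fold lower number from compound 1 to compound 4 (0.75 log units; beyond the scatter)). Nothing shown accounts for these differences.

The compounds shown leave open whether the fluorine or the placement of the ring nitrogen separates compound 4 from compound 2. From the compounds shown here alone, how a plain pyridin-4-yl or a ring bearing an amine would read also remains open.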